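The source may report more compounds than this note shows. Statements on the series, on what has been measured and on what is new or still open speak of the compounds shown alone.

Four close relatives are compared here. Compound 1 `CS/C(=N\C(=O)c1sccc1Cl)NC(=O)c1sccc1Cl` and compound 2 `CS/C(=N\C(=O)c1cc(-c2ccccc2)nc2ccccc12)NC(=O)c1cc(-c2ccccc2)nc2ccccc12` both carry a methylsulfanyl group on a carbon with a double bond to nitrogen, but the difference between the two cores is not broken down here. Compound 3 `C[Se]/C(=N\C(=O)c1cc(-c2ccccc2)nc2ccccc12)NC(=O)c1cc(-c2ccccc2)nc2ccccc12` is compound 2 with a group of 2 heavy atoms (1 carbon, 1 selenium; no ring) in place of a group of 2 heavy atoms (1 carbon, 1 sulfur; no ring), on a carbon with a double bond to nitrogen. Compound 4 `C[Se]/C(=N\C(=O)c1sccc1Cl)NC(=O)c1sccc1Cl` is compound 1 with the same change, (a group of 2 heavy atoms (1 carbon, 1 selenium; no ring) in place of a group of 2 heavy atoms (1 carbon, 1 sulfur; no ring), on a carbon with a double bond to nitrogen).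

In a functional assay on HT-29 cells (Homo sapiens) for cytotoxicity, read by MTT assay, with a stated time of 72 h (a lower number here means that less compound is tolerated, a higher number that more compound is tolerated), compound 1 gives only > 100000 nM, which is a limit of the assay and not a number. Compound 2 likewise gives only the limit > 100000 nM in this assay. Compound 3 gives 90700 nM in this assay. The measured step is an at least 1.1-fold lower number from compound 2 to compound 3 (0.04 log units; that floor lies within the scatter), and since its floor lies within the scatter, compound 2 and compound 3 cannot be told apart; the reading for compound 3 sits close to the limit of > 100000 nM in this assay, at which 2 of the 3 values shown sit.

The same change is now made on the core of compound 1. Because compound 1 gives only the limit > 100000 nM in this assay, compound 4 is expected to land near that limit as well. Because the measured step of an at least 1.1-fold lower number from compound 2 to compound 3 (0.04 log units; that floor lies within the scatter) stayed within the scatter, the change is not expected to move compound 4 far from its parent. The expected step is a step that the limit leaves unreadable from compound 1 to compound 4. Compound 4 is estimated at 120000 nM in this assay, with a range from 60000 nM to 300000 nM, and a fair chance that only a limit is reported.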

Compound 4, concentration lethal to 50% of the cells: > 100000 nM
Compound 4 ended at the assay's limit; the forecaster's own chance of this, stated with the estimate: 60%; the middle value lies beyond the limit too.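

No step can be read from compound 1 to compound 4, because both give only a limit of the assay and not a number: the limit of > 100000 nM in this assay, at which 3 of the 4 values shown sit. The compounds shown leave open whether putting the selenium-containing group in place of methylsulfanyl changes the reading on the core of compound 1 at all, and how compound 1 and compound 4 rank against each other.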